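This account rests on a few compounds, and the source may have more. Where it says the series, first, only, none or still open, it means among the compounds named here.

Measured so far:
- compound 1 `O=C(Nc1cccc(-n2cc(-c3ccncc3)c(-c3cc(O)cc(Cl)c3)n2)c1)Nc1ccc(Cl)c(C(F)(F)F)c1`: 8.99%
- compound 2 `COc1cc(Cl)cc(-c2nn(-c3cccc(NC(=O)Nc4ccc(Cl)c(C(F)(F)F)c4)c3)cc2-c2ccncc2)c1`: 13.5%
- compound 3 `COc1cc(Cl)cc(-c2nn(-c3cccc(NC(=O)Nc4cc(C(F)(F)F)cc(C(F)(F)F)c4)c3)cc2-c2ccncc2)c1`: -41.1%

In a functional assay on HOP-62 cells (Homo sapiens) for inhibition, read by sulforhodamine B assay, with a stated time of 48 h, tested at 10 uM (a higher number here means a weaker effect of the compound at the concentration tested, a lower number a stronger effect), compound 2 stands highest of the three numbers. Among the measured compounds shown here, compound 1 lies nearest, and the one change between them, a number 4.5 percentage points higher from compound 1 to compound 2 (within the scatter), stays within the scatter. Compound 3 lies far below, beyond the scatter; the two values show that a different group on the far end of the urea can shift the read-out a long way.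

Compound 4 `COc1cc(Cl)cc(-c2nn(-c3cccc(NC(=O)c4cccc(C(F)(F)F)c4)c3)cc2-c2ccncc2)c1` is not yet measured. Compared with compound 2 it carries 3-(trifluoromethyl)phenyl in place of (4-chloro-3-(trifluoromethyl)phenyl)amino on a carbonyl carbon. No measured step bears on this change: the only shown step concerns a methyl on an oxygen, not the urea end. So the expected step of a number 1.5 percentage points higher from compound 2 to compound 4 (within the scatter) is small, with wide uncertainty. For compound 4 the estimate is 15%, between -20% and 45%.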

Compound 4, a percentage reported as activity, at one concentration (the size of the read-out at that concentration, not a potency): 71.6%
Compound 4: middle estimate off by 56.6 percentage points, on the low side, outside the stated range (above it).
By their numbers in this assay, from the lowest: compound 3; then compounds 1 and 2 (each within the scatter of the next); then compound 4.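

In this assay, replacing the urea end of compound 2 with a directly attached 3-(trifluoromethyl)phenyl gives a number 58.1 percentage points higher from compound 2 to compound 4 (beyond the scatter), so this end can also sharply weaken the effect at the concentration tested. The step removes both the amino nitrogen, with its hydrogen-bond donor, and the chlorine, so it cannot show which loss matters. No measurement at hand explains the step. Still open, going by these compounds, is whether the chlorine alone, kept on the ring without the amino nitrogen, would change the read-out, and how a morpholine or a carboxylic acid would behave on this carbonyl carbon.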